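Chloro in Place of Bromo: From Compound 2 to Compound 4

A few compounds are considered here, and "the series" means these few. Any claim that something is new, unique, unknown or untested is made for them only; others in the source may bear on it.

Compound 2 `O=S(=O)(NCCNc1nccc(-c2c(-c3cccc(F)c3)nc3sccn23)n1)c1ccc(Br)cc1` has been run in a functional assay on SK-MEL-28 cells (Homo sapiens) for cytotoxicity, read by MTT assay (a higher number here means a weaker inhibitor, a lower number a stronger inhibitor), where compound 2 gives 13500 nM. Among the three compounds measured, compound 2 holds the highest number; its nearest neighbour is compound 1 `O=S(=O)(NCCCNc1nccc(-c2c(-c3cccc(F)c3)nc3sccn23)n1)c1ccc(Br)cc1`, which in this assay gives 9400 nM, and the furthest is compound 3 `COc1ccc(S(=O)(=O)NCCCNc2nccc(-c3c(-c4cccc(F)c4)nc4sccn34)n2)cc1`, which in this assay gives 8980 nM. Both gaps lie within the scatter, so the three compounds cannot be ordered against one another. The two measured steps are a 1.4-fold higher number from compound 1 to compound 2 (0.16 log units; within the scatter) and a 1.0-fold lower number from compound 1 to compound 3 (0.02 log units; within the scatter), each of them within the scatter.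

Compound 4 `O=S(=O)(NCCNc1nccc(-c2c(-c3cccc(F)c3)nc3sccn23)n1)c1ccc(Cl)cc1` differs from compound 2 by chloro in place of bromo on an aromatic carbon. For the measured compounds named here, no measured step exchanges one halogen for another; the closest precedent is the exchange of bromo for methoxy recorded as a 1.0-fold lower number from compound 1 to compound 3 (0.02 log units; within the scatter), which moved nothing beyond the scatter, and the shortening of the chain recorded as a 1.4-fold higher number from compound 1 to compound 2 (0.16 log units; within the scatter) was equally quiet. Every change so far made on the ((4-bromophenyl)sulfonyl)amino side of the shared core has left the read-out essentially unchanged. The step of a 1.0-fold lower number from compound 2 to compound 4 (0.02 log units; within the scatter) is therefore expected to stay within the scatter. Compound 4 is estimated at 13000 nM, with a range from 7000 nM to 25000 nM.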

Compound 4, half-maximal inhibitory concentration: 18600 nM
The estimate for compound 4 lay 1.4-fold (0.16 log units) below the measured number, within the range that was stated.
By their numbers in this assay, from the lowest: compounds 3, 1, 2 and 4 (each within the scatter of the next, the first and the last beyond it).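

In this assay, the exchange of one halogen for another on the aromatic carbon para to a large group gives a 1.4-fold higher number from compound 2 to compound 4 (0.14 log units; within the scatter) and stays within the scatter, so this read-out does not separate bromo from chloro at this place and compound 2 and compound 4 cannot be ordered. The chain change and the halogen exchange taken together give a 2.0-fold higher number from compound 1 to compound 4 (0.30 log units; within the scatter) and also remain within the scatter, so even these two differences combined do not yield a step that can be read as a real change. Nothing available bears on why the read-out responds so little to these changes.

From the compounds shown here alone, it remains open whether a group of a different kind at this position, such as an amine or a carboxylic acid, would move the number beyond the scatter, and whether methoxy would behave on the shorter chain of compound 2 as it does on the chain of compound 1. A longer chain than that of compound 1 is also untested among the compounds shown, so how far the chain can be extended before the number shifts is unknown.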